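Dropping One Methoxy Group from Compound 1

The source may hold more compounds than are shown below. What is called first, only, known or untested is meant among the compounds shown, and "the series" means these compounds.

Of the compounds shown here, three have been tested in a functional assay on OVCAR-8 cells (Homo sapiens) for cytotoxicity, read by sulforhodamine B assay, with a stated time of 48 h, tested at 0.1 uM; on this read-out higher numbers stand for a weaker effect at the one concentration tested and lower numbers for a stronger effect. Compound 1 `COc1cc(-c2cc(/C=C/C(=O)c3ccc(N)cc3)[nH]n2)cc(OC)c1OC` gives 98% in this assay, compound 2 `COc1ccc(C(=O)/C=C/c2cc(-c3cc(OC)c(OC)c(OC)c3)n[nH]2)cc1OC` gives 92%, and compound 3 `COc1ccc(C(=O)/C=C/c2cc(-c3cc(OC)c(OC)c(OC)c3)n[nH]2)cc1` gives 98%. All three values lie within the usual scatter of one another: a number 6 percentage points lower from compound 1 to compound 2 (within the scatter), and no change at the digits printed from compound 1 to compound 3 (within the scatter).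

Compound 4 `COc1ccc(-c2cc(/C=C/C(=O)c3ccc(N)cc3)[nH]n2)cc1OC` has not been measured yet. It differs from compound 1 by hydrogen in place of methoxy on an aromatic carbon. The same kind of change is already seen between two measured compounds: compound 3 differs from compound 2 by hydrogen in place of methoxy on an aromatic carbon, with a number 6 percentage points higher from compound 2 to compound 3 (within the scatter). The surroundings are not identical, though: in compound 1 the leaving methoxy also sits meta to a methoxy group, which is not the case in compound 2. The two cores differ as well, compound 1 differing from compound 2 by 4-aminophenyl in place of 3,4-dimethoxyphenyl on a carbonyl carbon.

Because the step of a number 6 percentage points higher from compound 2 to compound 3 (within the scatter) is within the scatter, and because compound 1 already gives 98%, compound 4 is expected to stay at a similar level, no change at the digits printed from compound 1 to compound 4 (within the scatter). The estimate for compound 4 in this assay is 98%, with a range from 88% to 106%.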

Compound 4, a percentage reported as activity, at one concentration (the size of the read-out at that concentration, not a potency): 99%
Compound 4: middle estimate off by 1 percentage points, on the low side; low and high end bracket the measured number.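

Replacing the methoxy group with hydrogen gives, in this assay, a number 1 percentage points higher from compound 1 to compound 4 (within the scatter). Set beside the earlier case, the same change reads alike on the two cores: the same change on two cores in this assay, a number 6 percentage points higher (within the scatter) from compound 2 to compound 3 and a number 1 percentage points higher (within the scatter) from compound 1 to compound 4, 5 percentage points apart, within the scatter of two such steps This agreement shows only that the change stays within the scatter on both cores at the one concentration tested; it does not show that the two cores would respond alike at another concentration, or that the change would carry over to a core on which a step beyond the scatter could be seen.

The compounds shown leave open what other groups would do in the place of this methoxy group, such as a hydroxyl group, a fluorine atom or a longer chain like ethoxy. They also leave open whether an amide or a carboxylic acid in place of the amino group of compound 4 would give a step beyond the scatter in this assay.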